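Chain length and amine substitution on the shared core

The compounds below may be only part of what the source reports. "The series", "measured", "known", "first", "only" and "open" are said of these compounds alone.

Compound 2 `CN(C)CCNC1=Nc2ccc(Cl)cc2C(C)(C)C1` gives 7000 nM in a functional assay on MDA-MB-231 cells (Homo sapiens) for cytotoxicity, read by MTT assay, with a stated time of 72 h, in the absence of a further agent (a higher number here means a weaker inhibitor, a lower number a stronger inhibitor), the highest of the two numbers measured, with compound 1 `CN(C)CCCNC1=Nc2ccc(Cl)cc2C(C)(C)C1` as its nearest neighbour at 2100 nM. Among the compounds with values here, the one measured step, a 3.3-fold higher number from compound 1 to compound 2 (0.52 log units; beyond the scatter), came from dimethylamino in place of (dimethylamino)methyl on a saturated chain carbon, two bonds along the chain from an amine nitrogen.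

Compound 3 `CCN(CC)CCCNC1=Nc2ccc(Cl)cc2C(C)(C)C1` reverses that change and adds ethyl groups on the terminal amine: (diethylamino)methyl in place of dimethylamino on a saturated chain carbon, two bonds along the chain from an amine nitrogen. From the compounds shown here alone, the step from compound 1 to compound 2 bears directly on the chain part of this change, since compound 3 carries the same chain as compound 1; for the exchange of methyl for ethyl on the amine nothing has been measured, so a shift in either direction beyond the scatter remains open. Compound 3 is therefore expected to move back toward compound 1, a 4.4-fold lower number from compound 2 to compound 3 (0.64 log units; beyond the scatter), with an estimate of 1600 nM in this assay and a range of 500 nM to 5000 nM.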

Compound 3, half-maximal inhibitory concentration: 2000 nM
Compound 3: middle estimate off by 1.3-fold (0.10 log units), on the low side; low and high end bracket the measured number.
By their numbers in this assay, from the lowest: compounds 3 and 1 (each within the scatter of the next); then compound 2.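

In this assay, diethylamino in place of dimethylamino on a saturated chain carbon, three bonds along the chain from an amine nitrogen, gives a 1.1-fold lower number from compound 1 to compound 3 (0.02 log units; within the scatter), so this exchange on the terminal amine leaves the number within the scatter. Within the data shown here, the change of (diethylamino)methyl in place of dimethylamino gives a 3.5-fold lower number from compound 2 to compound 3 (0.54 log units; beyond the scatter), which runs opposite to a 3.3-fold higher number from compound 1 to compound 2 (0.52 log units; beyond the scatter); with the ethyl exchange within the scatter on the longer chain, chain length is the only change seen so far to move the number beyond the scatter. Nothing at hand bears on the cause of these steps.

From the compounds shown here alone, whether diethylamino behaves the same way on the shorter chain stays open. Also open, going by these compounds, are a longer chain and a cyclic amine such as piperidine or morpholine in place of diethylamino.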